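Cyclopropylmethoxy to benzyloxy on a shared nitrile core

The source may hold more compounds than are shown below. What is called first, only, known or untested is meant among the compounds shown, and "the series" means these compounds.

Measured compounds:
compound 1 `COc1cc(C#N)cc(-n2nnc(-c3ccccn3)n2)c1`: 10 nM
compound 2 `N#Cc1cc(OCC2CC2)cc(-n2nnc(-c3ccccn3)n2)c1`: 975 nM

In a functional assay with metabotropic glutamate receptor 5 (Rattus norvegicus) as the target (a higher number here means a weaker inhibitor, a lower number a stronger inhibitor), compound 2 stands highest of the two numbers, with compound 1 nearest. For the measured compounds named here, the one measured step, a 98-fold higher number from compound 1 to compound 2 (1.99 log units; beyond the scatter), is the only guide. Compound 3 `N#Cc1cc(OCc2ccccc2)cc(-n2nnc(-c3ccccn3)n2)c1` differs from compound 2 by phenyl in place of cyclopropyl on a saturated chain carbon bound to an oxygen on an aromatic ring. This change continues in the direction that cost potency before, so a further rise, or at most no shift beyond the scatter, is expected rather than a recovery. Compound 3 is estimated at 2000 nM, within 500 nM to 8000 nM. From compound 2 this means an expected step of a 2.1-fold higher number from compound 2 to compound 3 (0.31 log units; beyond the scatter).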

Compound 3, half-maximal inhibitory concentration: > 1000 nM
Compound 3 was reported as a limit (the forecaster's own chance of this, stated with the estimate: 25%); the middle value lies beyond the limit too.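

In this assay compound 3 gives > 1000 nM, which is a limit of the assay and not a number. Phenyl in place of hydrogen on this chain carbon gives an at least 100-fold higher number from compound 1 to compound 3 (2.00 log units; beyond the scatter), so a six-membered aromatic ring there, like cyclopropyl, falls far short of the methoxy group. Phenyl in place of cyclopropyl gives an at least 1.0-fold higher number from compound 2 to compound 3 (0.01 log units; that floor lies within the scatter), and this floor does not tell the two groups apart.

From the compounds shown here alone, how far the value of compound 3 lies past its limit remains open. So does the effect of an ethyl group or a longer chain on this carbon, or of an amine at the end of such a chain.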